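Imine-carbon methyl swap carried from one core to another

The compounds below may be only part of what the source reports. "The series", "measured", "known", "first", "only" and "open" are said of these compounds alone.

Measured in a functional assay on U-937 cells (Homo sapiens) for antiproliferative activity, read by CCK-8 assay, with a stated time of 24 h; a higher number here means a weaker inhibitor, a lower number a stronger inhibitor:
compound 1 `CCN(CC)Cc1ccc2nc(NC(=O)N/N=C/c3ccccn3)sc2c1`: 24800 nM
compound 2 `CCN(CC)Cc1ccc2nc(NC(=O)N/N=C(\C)c3ccccn3)sc2c1`: 15600 nM
compound 3 `CC1CCN(Cc2ccc(NC(=O)N/N=C/c3ccccn3)cc2)CC1`: > 40000 nM

Within the core of compound 1, the change to compound 2 is a group of 9 heavy atoms (7 carbon, 2 nitrogen; one six-membered aromatic ring with 1 hetero atom) in place of a group of 8 heavy atoms (6 carbon, 2 nitrogen; one six-membered aromatic ring with 1 hetero atom), on an amide-type nitrogen. That step came out as a 1.6-fold lower number from compound 1 to compound 2 (0.20 log units; within the scatter), so the two values cannot be separated. Compound 3 is built on another core; the difference between the two cores is not broken down here. For compound 3 the value in this assay is only a limit of the assay, namely (the limit of > 40000 nM in this assay, at which 1 of the 3 values shown sits), and no number sits behind it.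

Compound 4 `C/C(=N\NC(=O)Nc1ccc(CN2CCC(C)CC2)cc1)c1ccccn1` is not yet measured. Relative to compound 3 it carries a group of 9 heavy atoms (7 carbon, 2 nitrogen; one six-membered aromatic ring with 1 hetero atom) in place of a group of 8 heavy atoms (6 carbon, 2 nitrogen; one six-membered aromatic ring with 1 hetero atom), on an amide-type nitrogen, the same change as that made from compound 1 to compound 2, at the same place. The step expected from compound 3 to compound 4 in this assay is a number no higher from compound 3 to compound 4 (the limit leaves the size open), resting on the earlier 1.6-fold lower number from compound 1 to compound 2 (0.20 log units; within the scatter), which stayed within the scatter. Because compound 3 gave > 40000 nM as a limit, compound 4 is expected near 40000 nM, between 15000 nM and 100000 nM, and a limit rather than a number is the more likely outcome for compound 4.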

Compound 4, half-maximal inhibitory concentration: > 40000 nM
Compound 4 was reported as a limit; the forecaster's own chance of this, stated with the estimate: 60%; the middle value sits exactly at the limit.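

No step can be read between compound 3 and compound 4, since both are reported only as limits in this assay and neither gives a number: the limit of > 40000 nM in this assay, at which 2 of the 4 values shown sit.

Left open is whether the change on the amide-type nitrogen alters the result at all on the core of compound 3, and how far either compound lies beyond the limit.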